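The compounds below may be only part of what the source reports. "The series", "measured", "known", "first", "only" and "open" are said of these compounds alone.

Compound 1 `CCc1cccc(C)c1-n1nncc1CN1C(=O)C2(C(C#N)=C(N)Oc3c(N)cc4nc5ccccc5nc4c32)c2ccccc21` and compound 2 `N#CC1=C(N)Oc2c(N)cc3nc4ccccc4nc3c2C12C(=O)N(Cc1cnnn1-c1c(F)cccc1F)c1ccccc12` share one core and differ only in the group on the aromatic nitrogen. In a functional assay on HCT-116 cells (Homo sapiens) for antiproliferative activity, read by MTT assay, with a stated time of 48 h (on this read-out higher numbers stand for weaker inhibition and lower numbers for stronger inhibition), compound 1 gives > 50000 nM, which is a limit of the assay and not a number. In this assay compound 2 likewise gives > 50000 nM, again a limit. The step that the two limits leave unreadable from compound 1 to compound 2 is therefore of unknown size. Compound 2 stands where both values shown sit, at the limit of > 50000 nM in this assay, at which 2 of the 2 values shown sit. Compound 3 `N#CC1=C(N)Oc2c(N)cc3nc4ccccc4nc3c2C12C(=O)N(Cc1cnnn1-c1ccc(Cl)cc1[N+](=O)[O-])c1ccccc12` is not yet measured and carries 4-chloro-2-nitrophenyl in place of 2,6-difluorophenyl on an aromatic nitrogen. Among the measured compounds shown here, the only step that bears on this change is the one from compound 1 to compound 2, and since both of its ends are limits its size cannot be read. The step from compound 2 to compound 3 is expected to be a step that the limit leaves unreadable from compound 2 to compound 3 in this assay, not separable from the scatter. Compound 3 is therefore expected to give 60000 nM in this assay, within a range from 20000 nM to 200000 nM, most likely again reported only as a limit.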

Compound 3, half-maximal inhibitory concentration: 28700 nM
Estimate against measurement, compound 3: 2.1-fold (0.32 log units) above, and the stated range covers the measured number.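

In this assay, among the compounds shown here, compound 3, with 4-chloro-2-nitrophenyl on the aromatic nitrogen, gives 28700 nM, the first value at this position that is a number and not a limit. Against the 2,6-difluorophenyl group the change reads as an at least 1.7-fold lower number from compound 2 to compound 3 (0.24 log units; that floor lies within the scatter), and against the 2-ethyl-6-methylphenyl group it reads as an at least 1.7-fold lower number from compound 1 to compound 3 (0.24 log units; that floor lies within the scatter), so each step has only a floor and neither is shown to lie beyond the scatter. The other two compounds remain unreadable as numbers, and the step between them cannot be read: the limit of > 50000 nM in this assay, at which 2 of the 3 values shown sit.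

Going by these compounds, whether the step belongs to the chloro or to the nitro substituent stays open, and a 4-chlorophenyl and a 2-nitrophenyl group would separate the two. On these data alone, how an aminophenyl or a carboxyphenyl group would read at this position also stays open.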